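The compounds below may be only part of what the source reports. "The series", "measured", "known", "first", "only" and "open" are said of these compounds alone.

Measured compounds in a functional assay on MIA PaCa-2 cells (Homo sapiens) for cytotoxicity, read by MTT assay, with a stated time of 72 h; on this read-out higher numbers stand for an effect only at larger amounts of compound and lower numbers for an effect already at smaller amounts:
Compound 1 `COc1ccc(/C=C2\C(=O)N(c3c(Cl)cccc3Cl)c3ccccc32)cc1`: in this assay compound 1 sits at the limit > 100 ug/mL, a limit and not a number.
Compound 2 `O=C1/C(=C\c2cccc(Br)c2)c2ccccc2N1c1c(Cl)cccc1Cl`: in this assay compound 2 gives 5 ug/mL.

Compound 2 holds the only number shown in this assay; the other value is a limit. Among the measured compounds shown here, the single measured step, an at least 20-fold lower number from compound 1 to compound 2 (1.30 log units; beyond the scatter), was large and came from exchanging one aryl group for another on the same chain carbon.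

Compound 3 `O=C1/C(=C\c2ccccc2[N+](=O)[O-])c2ccccc2N1c1c(Cl)cccc1Cl` differs from compound 2 by 2-nitrophenyl in place of 3-bromophenyl on a double-bonded chain carbon bound to a double-bonded ring carbon. For the measured compounds named here, the one measured step bears on it only loosely, since it exchanged a different pair of aryl groups; it shows that such swaps can move this assay strongly, and the value of compound 1 sits at the limit of > 100 ug/mL in this assay, at which 1 of the 2 values shown sits. Going by the values given here, no measured step sets a direction for the nitro change, so a step of no more than moderate size is expected, with compound 3 estimated at 8 ug/mL (range 2 ug/mL to 40 ug/mL), meaning an expected step of a 1.6-fold higher number from compound 2 to compound 3 (0.20 log units; within the scatter).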

Compound 3, concentration for half-maximal effect: 5 ug/mL
Beside the measured number, compound 3's estimate is 1.6-fold (0.20 log units) above it; measured number inside the range.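

In this assay, the 2-nitrophenyl and 3-bromophenyl groups on the double-bonded chain carbon read alike, with no change at the digits printed from compound 2 to compound 3 (within the scatter), so this place accepts two different aryl groups without a visible difference. The contrast with 4-methoxyphenyl is also no longer tied to the 3-bromophenyl group alone, as the second exchange gives an at least 20-fold lower number from compound 1 to compound 3 (1.30 log units; beyond the scatter), and among the three compounds only compound 1 goes against the shared reading. The value of compound 1 is a limit and not a number, so the true size of both steps from it stays unknown: the limit of > 100 ug/mL in this assay, at which 1 of the 3 values shown sits.

Open, going by these compounds, is whether an aminophenyl or a carboxyphenyl group on this chain carbon would read like compound 2 and compound 3. Also open, on these data alone, is whether 3-nitrophenyl would read like 2-nitrophenyl.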